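The source may hold more compounds than are shown below. What is called first, only, known or untested is meant among the compounds shown, and "the series" means these compounds.

Measured so far in an ADME assay on microsomes from liver (Mus musculus) for metabolic stability, read by LC-MS, with a stated time of 30 min, tested at 1 uM; on this read-out lower numbers stand for a less stable compound and higher numbers for a more stable compound:
compound 1 `O=C(NCc1ccc(S(=O)(=O)c2cccc(C(F)(F)F)c2)cc1)c1cc2cnccc2[nH]1` gives 49%
compound 2 `O=C(NCc1ccc(S(=O)(=O)c2ccccc2)cc1)c1cc2cnccc2[nH]1` gives 54%

Compound 2 stands within the scatter of compound 1, so the pair sets no order. Compound 3 `O=C(NCc1ccc(S(=O)(=O)c2ccc(F)cc2)cc1)c1cc2cnccc2[nH]1` differs from compound 2 by fluoro in place of hydrogen on an aromatic carbon, para to a large group. Going by the values given here, the only measured step bearing on this is a number 5 percentage points higher from compound 1 to compound 2 (within the scatter), also a swap on an aromatic carbon, and a single step is thin evidence. In this assay no shift beyond the scatter is expected, in either direction. The expected step is a number 2 percentage points higher from compound 2 to compound 3 (within the scatter) and no larger than the scatter. Compound 3 is estimated at 56% with 42% to 70% as the expected range.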

Compound 3, percent of the compound remaining: 72%
Compound 3: middle estimate off by 16 percentage points, on the low side; measured number above the stated range.
By their numbers in this assay, from the lowest: compounds 1 and 2 (each within the scatter of the next); then compound 3.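

In this assay, going by these compounds alone, the change from phenyl to 4-fluorophenyl gives a number 18 percentage points higher from compound 2 to compound 3 (beyond the scatter) and is the first change to clear the scatter, so this ring does respond to what it carries. Set against 3-(trifluoromethyl)phenyl on the sulfonyl sulfur, 4-fluorophenyl gives a number 23 percentage points higher from compound 1 to compound 3 (beyond the scatter) while plain phenyl showed no separation from that group. Nothing available accounts for the rise.

Still open, on these data alone, is whether fluoro is special at this place or whether chloro, methyl or methoxy there would do the same. Also open, as far as these compounds go, is how fluoro would read at other places on this ring.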